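The source may report more compounds than this note shows. Statements on the series, on what has been measured and on what is new or still open speak of the compounds shown alone.

Working notes on the hydroxamic acid series. Compound 1 `Cc1ccc(C(=O)NO)cc1F` carries a methyl group and a fluoro group on the shared core; in an assay on Sf9 cells for inhibition of protein deacetylase HDAC6 (Homo sapiens), read by fluorescence (on this read-out lower numbers stand for stronger inhibition and higher numbers for weaker inhibition), compound 1 gives 49 nM. Compound 2 `CC(=O)Nc1ccc(C(=O)NO)cc1` carries an acetamido group and no fluoro; in this assay compound 2 gives 162 nM, the higher of the two numbers recorded so far, with compound 1 its nearest neighbour and the gap between them beyond the usual scatter. Compound 3 `CC(=O)Nc1ccc(C(=O)NO)cc1F` is compound 2 with a single change: fluoro in place of hydrogen on an aromatic carbon. Among the compounds with values here, no measured pair in the set isolates this change, so its size cannot be read from the data and is only a guess. For compound 3 the expected step is a 1.4-fold lower number from compound 2 to compound 3 (0.13 log units; within the scatter), small, if anything towards a lower number, and not clearly beyond the scatter. Compound 3 is therefore estimated at 120 nM, with a range from 50 nM to 300 nM.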

Compound 3, half-maximal inhibitory concentration: 58 nM
Estimate against measurement, compound 3: 2.1-fold (0.32 log units) above; the range from low to high includes it.
By their numbers in this assay, from the lowest: compounds 1 and 3 (each within the scatter of the next); then compound 2.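

In this assay, fluoro in place of hydrogen on the aromatic carbon ortho to the acetamido group and meta to the hydroxycarbamoyl group gives a 2.8-fold lower number from compound 2 to compound 3 (0.45 log units; beyond the scatter), which puts a first size on this change: modest, but beyond the scatter. With fluoro in place, acetamido in place of methyl gives a 1.2-fold higher number from compound 1 to compound 3 (0.07 log units; within the scatter), so these two groups are not told apart on this fluoro-bearing core. Nothing at hand speaks to why the fluoro step has this size.

Still open, going by these compounds, is whether chloro or a methoxy group on the same aromatic carbon would give a step like that of fluoro, and whether fluoro gives a step of this size when methyl stands in place of acetamido. On these data alone, it is also open whether an amine or a longer acyl chain in place of acetamido would stay level with compound 3.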